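From 2,4-difluorobenzyl to 2-hydroxy-3-methylbenzyl

The source may report more compounds than this note shows. Statements on the series, on what has been measured and on what is new or still open speak of the compounds shown alone.

Measured so far in a functional assay on B16 cells (Mus musculus) for antiproliferative activity, with a stated time of 72 h; a lower number here means a stronger inhibitor, a higher number a weaker inhibitor:
- compound 1 `OC[C@H]1O[C@@H](n2cnc3c(NCc4cccc(F)c4)ncnc32)[C@H](O)[C@@H]1O` gives "not determined" (no result reported) with no result reported
- compound 2 `OC[C@H]1O[C@@H](n2cnc3c(NCc4cccc(Br)c4)ncnc32)[C@H](O)[C@@H]1O` gives > 166000 nM as a limit
- compound 3 `OC[C@H]1O[C@@H](n2cnc3c(NCc4ccc(F)cc4F)ncnc32)[C@H](O)[C@@H]1O` gives > 166000 nM as a limit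

Compound 3 sits at > 166000 nM in this assay as a limit of the assay, not a number. Among the compounds with values here, the series so far shows the limit of > 166000 nM in this assay, at which 2 of the 3 values shown sit, and offers no exact value. Compound 4 `Cc1cccc(CNc2ncnc3c2ncn3[C@@H]2O[C@H](CO)[C@@H](O)[C@H]2O)c1O` keeps the shared core but carries 2-hydroxy-3-methylphenyl in place of 2,4-difluorophenyl on a saturated chain carbon bound to a nitrogen on an aromatic ring, and 2-hydroxy-3-methylphenyl in place of 2,4-difluorophenyl on a saturated chain carbon bound to a nitrogen on an aromatic ring counts that swap. Within the data shown here, the only measured step of this kind is a step that the two limits leave unreadable from compound 2 to compound 3 so it offers no size to carry over. With nothing to size it, the expected step of an at least 3.3-fold lower number from compound 3 to compound 4 (0.52 log units; beyond the scatter) is a cautious guess toward a stronger inhibitor, and another limit remains quite possible. Compound 4 is estimated at 50000 nM with an expected range of 3000 nM to 166000 nM in this series.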

Compound 4, half-maximal inhibitory concentration: > 166000 nM
Compound 4: only a limit was reported; the forecaster's own chance of this, stated with the estimate: 50%; middle value at least 3.3-fold (0.52 log units) away from the limit.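

No new step can be read: compound 4, like compound 2 and compound 3, is reported only as a limit of the assay, not a number, so the steps among them have no readable size. The compounds shown leave open whether any group at this place on the shared core gives an exact value in this assay: the limit of > 166000 nM in this assay, at which 3 of the 4 values shown sit.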